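The compounds below may be only part of what the source reports. "The series", "measured", "known", "first", "only" and "open" are said of these compounds alone.

Measured so far:
compound 1, `CC1(C)CC(=O)C2=C(C1)N(c1ccccc1)N=C(c1ccccc1)C2`: 26%
compound 2, `CC1(C)CC(=O)C(CC(=O)c2ccccc2)=C(NNC(=N)N)C1`: 76%

In a functional assay on the whole organism (strain CF) for inhibition, with Mus musculus as the target, at a dose of 25 mg/kg by the oral route (on this read-out higher numbers stand for more inhibition at the one dose given (going by the name of the read-out) and lower numbers for less inhibition), compound 1 gives 26%, the lower of the two values shown, while compound 2 gives 76%, a gap beyond the usual scatter. Compound 3, `CC1(C)CC(=O)C2=C(C1)N(CCO)N=C(c1ccccc1)C2`, has not been measured. Its change from compound 1 is 2-hydroxyethyl in place of phenyl on an amine nitrogen in a ring. Among the compounds with values here, no measured pair shows this change, so the step is estimated without a direct precedent: the expectation is a number 4 percentage points higher from compound 1 to compound 3 (within the scatter), small and not clearly beyond the scatter in either direction. Compound 3 is therefore expected to give about 30%, in a range from 8% to 55%.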

Compound 3, a percentage reported as inhibition, in the whole organism at one dose (the size of the read-out at that dose, not a potency): 26%
Estimate against measurement, compound 3: 4 percentage points above, and the stated range covers the measured number.
By their numbers in this assay, from the lowest: compounds 1 and 3 (each within the scatter of the next); then compound 2.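

In this assay, putting 2-hydroxyethyl in place of phenyl on the amine nitrogen in a ring gives no change at the digits printed from compound 1 to compound 3 (within the scatter). At this one dose, then, the read-out does not depend on keeping the six-membered aromatic ring at this position, and a chain with no ring serves equally well. Nothing at hand explains this flat step.

Only these two groups are compared at this nitrogen, so a single step cannot show how far the position stays flat. On these data alone, whether a longer chain, an amine or a carboxylic acid there would move the number remains open.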